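Branched chain at the ring carbon: expected weakening

The compounds below may be only part of what the source reports. "The series", "measured", "known", "first", "only" and "open" are said of these compounds alone.

Three compounds of the series have numbers or outcomes in a functional assay on HL-60 cells (Homo sapiens) for antiproliferative activity, read by MTT assay; a lower number here means a stronger inhibitor, a higher number a weaker inhibitor. Among the measured compounds shown here, compound 3 `CCC[C@@H]1O[C@H](COCc2ccccc2)[C@@H](OCc2ccccc2)[C@H](OCc2ccccc2)[C@H]1O` is the only one with a single value: in this assay compound 3 gives 11700 nM, a weak result in itself. Compound 1 `CCCC[C@@H]1O[C@H](COCc2ccccc2)[C@@H](OCc2ccccc2)[C@H](OCc2ccccc2)[C@H]1O` differs from compound 3 only in its saturated chain. In this assay compound 1 is recorded as "not active" (no number reported). Compound 2 `CC(C)(C)C[C@@H]1O[C@H](COCc2ccccc2)[C@@H](OCc2ccccc2)[C@H](OCc2ccccc2)[C@H]1O`, again with a different saturated chain on the same shared core, is recorded in this assay as "not active" (no number reported). For the measured compounds named here, no step between measured compounds exists here, since the two outcomes without a number allow no computed size; they only show that the other chains gave nothing measurable where compound 3 gave a weak number.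

Compound 4 `CC(C)C[C@@H]1O[C@H](COCc2ccccc2)[C@@H](OCc2ccccc2)[C@H](OCc2ccccc2)[C@H]1O` is not yet measured. It differs from compound 3 by methyl in place of hydrogen on a saturated chain carbon bound to two saturated chain carbons.

The surrounding data give no sign that a larger chain helps: compound 1 and compound 2 are both without an active result. The step from compound 3 to compound 4 is therefore expected to go toward weaker, a 2.6-fold higher number from compound 3 to compound 4 (0.41 log units; beyond the scatter), beyond the usual scatter, with a real chance that only an inactive outcome is recorded. Compound 4 is estimated at 30000 nM, with a range of 10000 nM to 100000 nM.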

Compound 4, half-maximal inhibitory concentration: 8500 nM
Beside the measured number, compound 4's estimate is 3.5-fold (0.55 log units) above it; the measured number lies below the stated range.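

In this assay, methyl in place of hydrogen on a saturated chain carbon bound to two saturated chain carbons gives a 1.4-fold lower number from compound 3 to compound 4 (0.14 log units; within the scatter), so the propyl and isobutyl chains cannot be told apart at this level of activity. Among the compounds shown here, this is the first sign that the chain can carry this methyl and still give a number, whereas the chains of compound 1 and compound 2 gave only an outcome without one; branching as such therefore does not sort the series, since compound 4 keeps a value while compound 2, also branched, is recorded as "not active" (no number reported). No measurement on hand explains why these chains part in this way.

Still open, from the compounds shown here alone, is whether any change on this chain can move the activity beyond the scatter, since every number so far stays weak. An amine, a hydroxyl or a carboxylic acid at the chain, or a shorter ethyl chain on the shared core, would show whether this site accepts anything other than a small saturated chain and whether a stronger result can be reached from here.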